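The source may hold more compounds than are shown below. What is called first, only, known or untested is meant among the compounds shown, and "the series" means these compounds.

Of the compounds shown here, two sharing one core have been tested in a functional assay on M14 cells (Homo sapiens) for inhibition, read by sulforhodamine B assay, with a stated time of 48 h; on this read-out lower numbers stand for stronger inhibition of growth and higher numbers for weaker inhibition of growth. Compound 1, `COc1cc(-c2cc(/C=C/C(=O)c3ccc(Cl)c(Cl)c3)[nH]n2)cc(OC)c1OC`, gives 18200 nM in this assay, the higher of the two numbers. Compound 2, `COc1ccc(-c2cc(/C=C/C(=O)c3cc(OC)c(OC)c(OC)c3)[nH]n2)cc1OC`, gives 1800 nM, a lower number, and the gap between these two lies beyond the usual scatter of this assay. Compound 1 thus stands as the weaker inhibitor of growth of the pair.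

Compound 3, `COc1cc(-c2cc(/C=C/C(=O)c3ccc(F)c(F)c3)[nH]n2)cc(OC)c1OC`, has not yet been measured. Its difference from compound 1 is 3,4-difluorophenyl in place of 3,4-dichlorophenyl on a carbonyl carbon. For the measured compounds named here, only these two measured compounds are known, and none of them shows this particular exchange, so there is no measured step to lean on. The step from compound 1 to compound 3 is expected to be a 1.4-fold higher number from compound 1 to compound 3 (0.14 log units; within the scatter), which is not clearly beyond the scatter. Compound 3 is estimated at 25000 nM, in a range from 7000 nM to 90000 nM.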

Compound 3, concentration for 50% growth inhibition: 2700 nM
Compound 3: the middle estimate sits 9.3-fold (0.97 log units) above what was measured; the measured number lies below the stated range.
By their numbers in this assay, from the lowest: compounds 2 and 3 (each within the scatter of the next); then compound 1.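

In this assay, swapping the 3,4-dichlorophenyl group for a 3,4-difluorophenyl group on the carbonyl gives a 6.7-fold lower number from compound 1 to compound 3 (0.83 log units; beyond the scatter) and so shows that growth inhibition responds clearly to a change at this position. The two groups match in heavy atoms and in their six-membered aromatic ring of carbon only, and the exchange replaces chlorine with fluorine, so a change of halogen alone is enough to move the number here. Nothing measured here explains why the step runs in this direction.

Going by these compounds, this is a single pair, so it sets no trend across halogens, and 3,4-dibromophenyl, unsubstituted phenyl and an aminophenyl group in the same place remain open. Also open, on these data alone, is whether the same exchange would give a step of similar size with the other methoxy pattern seen in compound 2.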